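The source may hold more compounds than are shown below. What is called first, only, known or untested is meant among the compounds shown, and "the series" means these compounds.

The three compounds measured so far:

- Compound 1, `Nc1nc(O)c2c(n1)n(C1OC(CO)[C@@H](O)[C@H]1O)c(=O)n2C/C=C/c1ccccc1`, gives 5% in a functional assay on the whole organism with Mus musculus as the target; a lower number here means a smaller maximal response, a higher number a larger maximal response.
- Compound 2, `COc1ccc(Cn2c(=O)n(C3OC(CO)[C@@H](O)[C@H]3O)c3nc(N)nc(O)c32)cc1`, gives 14% in this assay.
- Compound 3, `CN(C)CCCn1c(=O)n(C2OC(CO)[C@@H](O)[C@H]2O)c2nc(N)nc(O)c21`, gives 63% in this assay.

Compound 3 stands highest of the three. Its lead over compound 2 is a number 49 percentage points higher from compound 2 to compound 3 (beyond the scatter), and over compound 1 it is a number 58 percentage points higher from compound 1 to compound 3 (beyond the scatter), both beyond the scatter. Between compound 1 and compound 2 the change is a number 9 percentage points higher from compound 1 to compound 2 (within the scatter), which lies within the scatter, so those two cannot be ranked against each other.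

Compound 4, `CCOC(=O)Cn1c(=O)n(C2OC(CO)[C@@H](O)[C@H]2O)c2nc(N)nc(O)c21`, has not yet been measured. It differs from compound 3 in one place: ethoxycarbonyl in place of 2-(dimethylamino)ethyl on a saturated chain carbon bound to an aromatic nitrogen.

For the measured compounds named here, two measured steps bear on this. In both a number 58 percentage points higher from compound 1 to compound 3 (beyond the scatter) and a number 49 percentage points higher from compound 2 to compound 3 (beyond the scatter) the arrival of the 2-(dimethylamino)ethyl group on that carbon brought a large rise in the maximal response. Compound 4 gives that group up again. Going by the values given here, no measured compound carries an ethoxycarbonyl group, so its own contribution is unknown; the only guide is that every compound without the 2-(dimethylamino)ethyl group sits low.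

The step from compound 3 to compound 4 is therefore expected to be a fall beyond the scatter, a number 43 percentage points lower from compound 3 to compound 4 (beyond the scatter). Compound 4 is estimated at 20%, with a range from 5% to 45%.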

Compound 4, largest response reached (reported as maximal response), in percent of the reference or control that the assay uses: 58%
Compound 4: the middle estimate sits 38 percentage points below what was measured, outside the stated range (above it).
By their numbers in this assay, from the lowest: compounds 1 and 2 (each within the scatter of the next); then compounds 4 and 3 (each within the scatter of the next).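

On a saturated chain carbon bound to an aromatic nitrogen, replacing 2-(dimethylamino)ethyl with ethoxycarbonyl gives a number 5 percentage points lower from compound 3 to compound 4 (within the scatter) in this assay, so a high maximal response here does not depend on the amine group that first seemed to set it. Ethoxycarbonyl also matches the earlier large gains: against 4-methoxyphenyl the result is a number 44 percentage points higher from compound 2 to compound 4 (beyond the scatter), and against 2-phenylethenyl it is a number 53 percentage points higher from compound 1 to compound 4 (beyond the scatter). The four compounds now fall into two pairs, with the low pair carrying a benzene ring in the changed group and the high pair carrying no ring, and no compound shown goes against this split, though the data offer no explanation for it.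

On these data alone, what remains open is whether the benzene ring holds the response down or the amine and the ester each raise it on their own, and a plain propyl chain, with neither nitrogen nor oxygen, would help to separate these two readings. A carboxylic acid in place of the ethyl ester, or a benzene ring set further out on a longer chain, would test how far the split holds.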